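Fluorine Placement on a Phenylurea Tested on Rice

A few compounds are considered here, and "the series" means these few. Any claim that something is new, unique, unknown or untested is made for them only; others in the source may bear on it.

The measured compounds and their values:
compound 1, `C[C@@H](NC(=O)Nc1ccccc1F)c1ccccc1`, 97%
compound 2, `C[C@@H](NC(=O)Nc1ccc(F)cc1)c1ccccc1`, 98%
compound 3, `C[C@@H](NC(=O)Nc1cccc(F)c1F)c1ccccc1`, 100%

Three ureas built on one shared core were tested in an ADME assay on the whole organism with Oryza sativa as the target, tested at 0.1 uM; on this read-out higher numbers stand for a weaker effect at the one concentration tested and lower numbers for a stronger effect. Compound 1, `C[C@@H](NC(=O)Nc1ccccc1F)c1ccccc1`, gives 97%. Compound 2, `C[C@@H](NC(=O)Nc1ccc(F)cc1)c1ccccc1`, gives 98%, and compound 3, `C[C@@H](NC(=O)Nc1cccc(F)c1F)c1ccccc1`, gives 100%. All three numbers lie within the usual scatter of one another, so the read-outs show no difference in effect that can be relied on.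

Compound 1 and compound 3 differ in one place, (fluoro in place of hydrogen on an aromatic carbon), and this change made a step of a number 3 percentage points higher from compound 1 to compound 3 (within the scatter). Compound 1 and compound 2 have the same atoms joined differently; the difference between these two cores is not broken down here.

Compound 4, `C[C@@H](NC(=O)Nc1ccc(F)c(F)c1)c1ccccc1`, has not yet been measured in this assay. It differs from compound 2 by fluoro in place of hydrogen on an aromatic carbon, the same change that turns compound 1 into compound 3, with the surroundings of the place described in the same words. Because the earlier step was a number 3 percentage points higher from compound 1 to compound 3 (within the scatter), the step from compound 2 to compound 4 in this assay is expected to be similarly small, a number 1 percentage points higher from compound 2 to compound 4 (within the scatter). On that basis compound 4 is estimated at 99%, expected to fall between 93% and 100%.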

Compound 4, a percentage reported as activity, at one concentration (the size of the read-out at that concentration, not a potency): 99%
Compound 4: the middle estimate sits on the measured number at the digits printed, within the range that was stated.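

In this assay, fluoro in place of hydrogen on an aromatic carbon, here ortho to a fluoro group and meta to a large group, gave a step of a number 1 percentage points higher from compound 2 to compound 4 (within the scatter). Set beside the earlier step, the same change behaved alike on the two cores, with no difference between the steps that can be relied on: the same change on two cores in this assay, a number 3 percentage points higher (within the scatter) from compound 1 to compound 3 and a number 1 percentage points higher (within the scatter) from compound 2 to compound 4, 2 percentage points apart, within the scatter of two such steps
Going by these compounds alone, this agreement is only between two steps that cannot be told from no step at all, and it shows neither that the added fluoro has a real effect on either core nor that the change would stay as small on a core outside these four compounds.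

All four compounds carry only fluoro on the varied ring, which leaves open whether a chloro, methoxy, nitrile, amine or carboxylic acid group there would give a read-out that stands apart from these values. They also share the same urea and the same other half of the core, and a single concentration cannot say whether any of them would differ from the others at another one.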